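Replacing 3-cyanophenyl with 1-methyl-1H-indol-5-yl

This account rests on a few compounds, and the source may have more. Where it says the series, first, only, none or still open, it means among the compounds named here.

Measured so far in a functional assay on B16-F0 cells (Mus musculus) for inhibition, read by CCK-8 assay, with a stated time of 48 h; on this read-out higher numbers stand for weaker inhibition and lower numbers for stronger inhibition
- Compound 1 `COc1cc(-c2ccnc3cc(-c4ccc(Cl)cc4)nn23)cc(OC)c1OC` gives 4090 nM
- Compound 2 `COc1cc(-c2ccnc3cc(-c4ccc(C)c(C)c4)nn23)cc(OC)c1OC` gives 391 nM
- Compound 3 `COc1cc(-c2ccnc3cc(-c4cccc(C#N)c4)nn23)cc(OC)c1OC` gives > 10000 nM as a limit

Compound 3 is reported only as a limit, the limit of > 10000 nM in this assay, at which 1 of the 3 values shown sits, and so has no number. Compound 4 `COc1cc(-c2ccnc3cc(-c4ccc5c(ccn5C)c4)nn23)cc(OC)c1OC` carries 1-methyl-1H-indol-5-yl in place of 3-cyanophenyl on an aromatic carbon and, like compound 2, has no nitrile. Among the compounds with values here, three measured steps bear on this change, all at the same place. Two are large, a 10-fold lower number from compound 1 to compound 2 (1.02 log units; beyond the scatter) and an at least 25-fold higher number from compound 2 to compound 3 (1.40 log units; beyond the scatter) while the third is at least modest, an at least 2.4-fold higher number from compound 1 to compound 3 (0.38 log units; beyond the scatter) and beyond the scatter. A large step to a lower number is expected in this assay because an at least 25-fold higher number from compound 2 to compound 3 (1.40 log units; beyond the scatter) shows a change of that size at this place. The estimate means an at least 66-fold lower number from compound 3 to compound 4 (1.82 log units; beyond the scatter) as an expected step. Compound 4 is estimated at 150 nM (25 nM to 1200 nM).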

Compound 4, half-maximal inhibitory concentration: 48 nM
The estimate for compound 4 lay 3.1-fold (0.49 log units) above the measured number; measured number inside the range.
By their numbers in this assay, from the lowest: compound 4; then compound 2; then compound 1. At a limit, above all of these: compound 3.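

In this assay, 1-methyl-1H-indol-5-yl outdoes both substituted phenyl groups with measured numbers at this place, giving an 8.1-fold lower number from compound 2 to compound 4 (0.91 log units; beyond the scatter) and an 85-fold lower number from compound 1 to compound 4 (1.93 log units; beyond the scatter). Compound 4 therefore has the lowest number of the four, and a two-ring aromatic group is accepted here. The step from the nitrile, an at least 200-fold lower number from compound 3 to compound 4 (2.31 log units; beyond the scatter), is only a minimum, as compound 3 is a limit: the limit of > 10000 nM in this assay, at which 1 of the 4 values shown sits.

From the compounds shown here alone, whether the methyl of 1-methyl-1H-indol-5-yl matters stays open. A hydrogen, an ethyl group or an aminoethyl chain in its place would test this.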